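The compounds below may be only part of what the source reports. "The series", "measured", "known", "first", "only" and "open" are said of these compounds alone.

Measured so far:
Compound 1 `COc1ccc(Nc2nn(Cc3ccc(C)cc3)c3cc(-c4c(C)noc4C)ccc23)cc1`: 11900 nM
Compound 2 `CNc1cc(-c2ccc3cnn(Cc4ccc(C)cc4)c3c2)cn(C)c1=O`: 3280 nM

Both values come from a functional assay on MV4-11 cells (Homo sapiens) for antiproliferative activity, read by luminescence and CellTiter-Glo, with a stated time of 72 h; on this read-out higher numbers stand for weaker inhibition and lower numbers for stronger inhibition. Compound 2 has the lower number of the two, so it is the stronger inhibitor of this pair, and the gap to compound 1 lies beyond the usual scatter. Still, two compounds give only a narrow view of the series.

The next compound is compound 3 `CNc1cc(-c2ccc3cnn(CC4CC4)c3c2)cn(C)c1=O`. It keeps the rest of compound 2 and has one change: cyclopropyl in place of 4-methylphenyl on a saturated chain carbon bound to an aromatic nitrogen. In other words, 4-methylbenzyl gives way to cyclopropylmethyl.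

Within the data shown here, no measured pair differs in one place, so the data give no direct size for this change. A modest shift towards a higher number in this assay is expected, which would mean somewhat weaker inhibition. The estimated change is a 1.5-fold higher number from compound 2 to compound 3 (0.18 log units; within the scatter), and it may not exceed the scatter. For compound 3 the expected value is 5000 nM, with an estimated range from 1500 nM to 15000 nM.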

Compound 3, half-maximal inhibitory concentration: 3450 nM
For compound 3 the middle estimate is 1.4-fold (0.16 log units) above the measured one, and the stated range covers the measured number.
By their numbers in this assay, from the lowest: compounds 2 and 3 (each within the scatter of the next); then compound 1.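

In this assay, putting cyclopropyl in place of 4-methylphenyl on a saturated chain carbon bound to an aromatic nitrogen gives a 1.1-fold higher number from compound 2 to compound 3 (0.02 log units; within the scatter), so this read-out does not separate the two compounds. Among these compounds, this is the only single-place comparison so far, and it shows that at this position a group of 3 heavy atoms and one of 7 heavy atoms give matching results, so an aromatic ring on this chain is not needed to keep this level of inhibition in this pair. Nothing available explains this result.

Going by these compounds, it remains open whether an amine, a carboxylic acid or a longer chain such as n-butyl at this position would move the number beyond the scatter. On these data alone, it is also open whether the same swap would give a matching result on the core of compound 1.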